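A few compounds are considered here, and "the series" means these few. Any claim that something is new, unique, unknown or untested is made for them only; others in the source may bear on it.

Measured so far:
compound 1 `c1cn2cc(-c3ccsc3)nc(-c3ccc4ncn(C5CCCCC5)c4c3)c2n1`: 1.36% in a functional assay on DU-145 cells (Homo sapiens) for inhibition, read by sulforhodamine B assay, with a stated time of 48 h, tested at 10 uM; on this read-out lower numbers stand for less inhibition and higher numbers for more inhibition at the one concentration tested (going by the name of the read-out)
compound 2 `Brc1ccc(-c2cn3ccnc3c(-c3ccc4ncn(C5CCCCC5)c4c3)n2)cc1`: 5.66% in this assay

Among the measured compounds shown here, compound 2 stands beside compound 1 on these two numbers; the only step on record, a number 4.3 percentage points higher from compound 1 to compound 2 (within the scatter), leaves them within the scatter of each other. Compound 3 `Fc1ccccc1-c1cn2ccnc2c(-c2ccc3ncn(C4CCCCC4)c3c2)n1` differs from compound 2 by 2-fluorophenyl in place of 4-bromophenyl on an aromatic carbon. For the measured compounds named here, the one step that bears on this position, from thiophen-3-yl to 4-bromophenyl, did not move the read-out beyond the scatter, and nothing else is known about this position. No step beyond the scatter is therefore expected in this assay. Compound 3 is estimated at 4%, between -6% and 15%, which means an expected step of a number 1.7 percentage points lower from compound 2 to compound 3 (within the scatter).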

Compound 3, a percentage reported as inhibition, at one concentration (the size of the read-out at that concentration, not a potency): 0.96%
Compound 3: middle estimate off by 3 percentage points, on the high side, and the stated range covers the measured number.
By their numbers in this assay, from the lowest: compounds 3, 1 and 2 (each within the scatter of the next).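

In this assay, a third group at this position gives no reading outside the scatter, with a number 4.7 percentage points lower from compound 2 to compound 3 (within the scatter) and a number 0.4 percentage points lower from compound 1 to compound 3 (within the scatter). Thiophen-3-yl, 4-bromophenyl and 2-fluorophenyl therefore read alike here, and exchanging bromine for fluorine while shifting the halogen on the phenyl ring leaves the number within the scatter. No evidence on hand explains this flat result. Still open, going by these compounds, is whether an amine or a carboxylic acid on the phenyl ring, or a longer chain in its place, would move the read-out beyond the scatter.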